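The source may report more compounds than this note shows. Statements on the series, on what has been measured and on what is new or still open speak of the compounds shown alone.

In a functional assay on Hs 683 cells (Homo sapiens) for cytotoxicity, read by MTT assay, with a stated time of 72 h (a higher number here means a weaker inhibitor, a lower number a stronger inhibitor), compound 1 `c1ccc2[nH]c(-n3cccn3)cc2c1` gives > 100000 nM, which is a limit of the assay and not a number. Its position is therefore known only as a limit, and no exact potency can be read from it. The other measured compound, compound 2 `Cc1ccc2[nH]c(-c3ccc[nH]3)c(C3CC(=O)NC3=O)c2c1`, gives a numerical reading of 8000 nM in this assay. For the measured compounds named here, no single-change step connects compound 2 to compound 1, so this value cannot size the change considered here.

Compound 3 `Cc1ccc2[nH]c(-n3cccn3)cc2c1` keeps the core of compound 1 and differs in one place: methyl in place of hydrogen on an aromatic carbon, with methyl in place of hydrogen on an aromatic carbon. Going by the values given here, with no measured step to calibrate this change, only a small effect is expected, and none beyond the usual scatter is the most likely outcome. The expected step is a number no higher from compound 1 to compound 3 (the limit leaves the size open). This expectation rests on compound 1 and on (the limit of > 100000 nM in this assay, at which 1 of the 2 values shown sits). A reading that again reaches the limit of this assay would therefore be unsurprising. For compound 3 the estimated value is 100000 nM, with an expected range from 30000 nM to 200000 nM.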

Compound 3, half-maximal inhibitory concentration: > 100000 nM
Compound 3: a limit, no number; the forecaster's own chance of this, stated with the estimate: 65%; the middle value lies on the limit itself.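

Compound 1 and compound 3 both give limits of the assay and not numbers in this assay, so no step between them can be read: the limit of > 100000 nM in this assay, at which 2 of the 3 values shown sit.

The compounds shown leave open what methyl in place of hydrogen on an aromatic carbon does to the potency of the core of compound 1 in this assay.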